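The source may hold more compounds than are shown below. What is called first, only, known or untested is meant among the compounds shown, and "the series" means these compounds.

Measured so far:
- Compound 1 `Cc1cn(C2CCN(Cc3cccc(OC4CCCCC4)c3)CC2)c(=O)[nH]c1=O`: 23600 nM
- Compound 2 `Cc1cn(C2CCN(Cc3cc(Oc4ccccc4)ccn3)CC2)c(=O)[nH]c1=O`: a limit, > 64000 nM
- Compound 3 `Cc1cn(C2CCN(Cc3cccc(Oc4ccncc4)c3)CC2)c(=O)[nH]c1=O`: "not determined" (no result reported)

In an ADME assay on MRC5 cells (Homo sapiens) for cytotoxicity, read by fluorescence and resazurin assay, with a stated time of 3 days (on this read-out lower numbers stand for stronger inhibition and higher numbers for weaker inhibition), compound 1 gives 23600 nM. For compound 2 this assay reports only a limit, > 64000 nM, and not a number. For compound 3 this assay records "not determined" (no result reported), so compound 3 stands without any number and cannot be placed against the others. Among the values shown, one sits at the limit of > 64000 nM in this assay, at which 1 of the 3 values shown sits, and that is the entry for compound 2. Going by the values given here, no two of the measured compounds differ in a single place, so no measured step is available to guide the next change.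

Compound 4 `Cc1cn(C2CCN(Cc3cccc(Oc4cccnc4)c3)CC2)c(=O)[nH]c1=O` differs from compound 3 in one place: pyridin-3-yl in place of pyridin-4-yl on an oxygen on an aromatic ring. Among the compounds with values here, because no step has been measured in this assay, there is no ground to expect a change beyond the usual scatter in either direction. The weak readings of compound 1 and compound 2 suggest that compound 4 will also read weakly. Compound 4 is estimated at 40000 nM, expected to lie between 15000 nM and 128000 nM.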

Compound 4, half-maximal inhibitory concentration: > 64000 nM
Compound 4: a limit, no number; the forecaster's own chance of this, stated with the estimate: 45%; middle value at least 1.6-fold (0.20 log units) from the limit.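

Going by these compounds alone, on the oxygen on an aromatic ring, pyridin-3-yl in place of cyclohexyl gives an at least 2.7-fold higher number from compound 1 to compound 4 (0.43 log units; beyond the scatter) in this assay, the only measured step at this position. Compound 4 gives a limit, > 64000 nM, not a number, so the step has a lower bound but no exact size. Compound 4 and compound 2 now stand at the same limit, so a second compound in this small set reads no cytotoxicity that can be given as a number: the limit of > 64000 nM in this assay, at which 2 of the 4 values shown sit.

The change from pyridin-4-yl to pyridin-3-yl cannot be read, since compound 3 has no result in this assay. On these data alone, it also remains open whether a small methyl group on that oxygen, or a ring carrying an amine or a carboxylic acid, would read as a number or stay at the limit.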